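The source may hold more compounds than are shown below. What is called first, only, known or untested is meant among the compounds shown, and "the series" means these compounds.

Compound 1 `Nc1ncc(-c2ccc(C(=O)N3CC(O)C3)cc2)nc1-c1ccc(C(F)(F)F)cc1`: > 90%
Compound 2 `Nc1ncc(-c2ccc(C(=O)N3CC[C@H](O)C3)cc2)nc1-c1ccc(C(F)(F)F)cc1`: > 90%

In an ADME assay on microsomes from liver (Rattus norvegicus) for metabolic stability, read by LC-MS, using NADPH, with a stated time of 30 min, tested at 0.1 uM, in the presence of a further agent that is not named here (a lower number here means that less of the compound is left, a higher number that more of the compound is left), compound 2 gives > 90%, which is a limit of the assay and not a number. Compound 1 gives > 90%, also a limit. The two compounds thus share one reading: the limit of > 90% in this assay, at which 2 of the 2 values shown sit. Going by the values given here, the only measured step is a step that the two limits leave unreadable from compound 1 to compound 2, so it offers no size to carry forward.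

Compound 3 `Nc1ncc(-c2ccc(C(=O)O)cc2)nc1-c1ccc(C(F)(F)F)cc1` is still unmeasured. It differs from compound 2 by hydroxy in place of 3-hydroxypyrrolidin-1-yl on a carbonyl carbon, which turns (3-hydroxypyrrolidin-1-yl)carbonyl into carboxy. Among the compounds with values here, the measured step swapped one ring for another at that carbonyl carbon, and no measured compound shows what losing the ring does. In this assay no change beyond the scatter is therefore expected, though the uncertainty reaches mainly downward. The expected change is a number at least 2 percentage points lower from compound 2 to compound 3 (that floor lies within the scatter). For compound 3 the estimated value is 88%, expected to fall between 65% and 100%.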

Compound 3, percent of the compound remaining: > 90%
Compound 3 was reported as a limit; the forecaster's own chance of this, stated with the estimate: 45%; middle value at least 2 percentage points away from the limit.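

No new step can be read among compound 1, compound 2 and compound 3 in this assay, because all three give the same reading, which is a limit and not a number: the limit of > 90% in this assay, at which 3 of the 3 values shown sit.

On these data alone, whether the three truly differ, and whether any change on the carbonyl carbon would give a readable number, stays open.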